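Imidazole replaces cyanopyrazole at the biaryl position

This account rests on a few compounds, and the source may have more. Where it says the series, first, only, none or still open, it means among the compounds named here.

Three compounds share one core and differ only in the group on the aromatic carbon meta to the methyl group. In a physicochemical assay for lipophilicity, at pH 7.4 (on this read-out lower numbers stand for lower lipophilicity and higher numbers for higher lipophilicity), compound 1 `Cc1ccccc1-c1ccc(-c2nnc(N(C)Cc3ccc4nccn4c3)o2)cc1` gives 4.7, compound 2 `Cc1cc(-c2c(C)n[nH]c2C)ccc1-c1nnc(N(C)Cc2ccc3nccn3c2)o1` gives 3.8, and compound 3 `Cc1cc(-c2c(C#N)nn(C)c2C)ccc1-c1nnc(N(C)Cc2ccc3nccn3c2)o1` gives 3.4, the lowest of the three. Within the data shown here, the one step at this position is a number 0.40 log units lower from compound 2 to compound 3 (beyond the scatter). Compound 4 `Cc1cc(-c2c(C)nc(C)n2C)ccc1-c1nnc(N(C)Cc2ccc3nccn3c2)o1` carries 1,2,4-trimethyl-1H-imidazol-5-yl in place of 3-cyano-1,5-dimethyl-1H-pyrazol-4-yl on an aromatic carbon. Among the measured compounds shown here, no measured step covers this exchange; the step from compound 2 to compound 3 touches the same place but a different change, so it gives only a loose guide. For compound 4 in this assay a value near that of compound 3 is expected, with a step of a number 0.10 log units higher from compound 3 to compound 4 (within the scatter) not beyond the scatter, estimated at 3.5 within 2.9 to 4.1.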

Compound 4, distribution coefficient: 2.6
Compound 4: middle estimate off by 0.90 log units, on the high side, and the stated range ends above it.
By their numbers in this assay, from the lowest: compound 4; then compound 3; then compound 2; then compound 1.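

At this position, the choice of five-membered ring matters more than the pyrazole pair suggested: in this assay, 1,2,4-trimethyl-1H-imidazol-5-yl gives a number 0.80 log units lower from compound 3 to compound 4 (beyond the scatter), and a number 1.20 log units lower from compound 2 to compound 4 (beyond the scatter). The exchange therefore extends the range reached with the two pyrazole groups, even though the entering group carries no nitrile. Nothing available explains the size of these steps.

From the compounds shown here alone, it remains open whether the imidazole ring itself or its methyl substitution sets the value. A 1-methyl-1H-imidazol-5-yl group or a morpholine at this position would help to separate these possibilities.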